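From 1-hydroxyethyl to acetoxymethyl on the shared core

This account rests on a few compounds, and the source may have more. Where it says the series, first, only, none or still open, it means among the compounds named here.

In a functional assay on NCI-H460 cells (Homo sapiens) for cytotoxicity, read by sulforhodamine B assay, with a stated time of 3 days (a higher number here means a weaker inhibitor, a lower number a stronger inhibitor), the measured compounds give:
Compound 1 `OCc1cn(Cc2ccc(Cl)cc2)c2ccccc12` gives 16 nM
Compound 2 `O=[N+]([O-])c1cccc(Cn2cc(CO)c3ccccc32)c1` gives 39 nM
Compound 3 `CC(O)c1cn(Cc2ccc(Cl)cc2)c2ccccc12` gives 25100 nM

Of these three, compound 3 has the highest number, and compound 2 and compound 1 both lie far lower. The next structure is compound 4 `CC(=O)OCc1cn(Cc2ccc(Cl)cc2)c2ccccc12` which differs from compound 3 by acetoxymethyl in place of 1-hydroxyethyl on an aromatic carbon with acetoxymethyl in place of 1-hydroxyethyl on an aromatic carbon.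

Among the compounds with values here, one measured step bears on this change. It is a 1600-fold higher number from compound 1 to compound 3 (3.20 log units; beyond the scatter) and it came with methyl in place of hydrogen on a saturated chain carbon bound to an aromatic carbon and an oxygen. Compound 4 carries no such methyl on that chain carbon, so a large move to a lower number in this assay is expected on the strength of that large step. Within the data shown here, no measured compound carries acetoxymethyl, however, so the full size of the move remains uncertain and the range must stay wide.

The expected change is a 170-fold lower number from compound 3 to compound 4 (2.22 log units; beyond the scatter) and this is only an estimate. For compound 4 the estimated value is 150 nM with 15 nM to 3000 nM as the expected range.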

Compound 4, half-maximal inhibitory concentration: 39 nM
Beside the measured number, compound 4's estimate is 3.8-fold (0.59 log units) above it; the range from low to high includes it.
By their numbers in this assay, from the lowest: compound 1; then compounds 2 and 4 (each within the scatter of the next); then compound 3.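

In this assay, moving from 1-hydroxyethyl to acetoxymethyl on this aromatic carbon of the shared core recovers nearly all of the ground lost with compound 3 (a 640-fold lower number from compound 3 to compound 4 (2.81 log units; beyond the scatter)), while putting acetyl in place of hydrogen on the oxygen of compound 1 has only a modest cost (a 2.4-fold higher number from compound 1 to compound 4 (0.39 log units; beyond the scatter)). Earlier, the compounds showed only that a methyl on the chain carbon came with a large rise; they did not show that this position could take a larger group and keep a low number, and acetoxymethyl, with 5 heavy atoms and 0 hydrogen-bond donors against the 3 heavy atoms and 1 donor of 1-hydroxyethyl, now shows that neither a small group nor a hydrogen-bond donor on it is required. No measurement shown here accounts for the wide gap between these two groups.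

The compounds shown leave open whether a longer acyl chain, a methyl ether or an amine in place of the acetoxy part would also keep the number low. They also leave open whether a methyl on the chain carbon would still carry so large a cost once the oxygen bears acetyl.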